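Hydroxy removal on the phenyl-triazole ester

This account rests on a few compounds, and the source may have more. Where it says the series, first, only, none or still open, it means among the compounds named here.

In a functional assay on DU-145 cells (Homo sapiens) for antiproliferative activity, read by MTT assay, with a stated time of 48 h (on this read-out lower numbers stand for stronger inhibition and higher numbers for weaker inhibition), compound 1 `C/C(=C\CC/C(C)=C/CC[C@@H]1[C@@]2(C)CCC(=O)C(C)(C)[C@H]2CC[C@@]1(C)O)CC/C=C(\C)C(=O)OCc1cn(-c2cccc(O)c2)nn1` gives 28400 nM, the lowest of the two numbers shown. Compound 2 `C#CCOC(=O)/C(C)=C/CC/C(C)=C/CC/C(C)=C/CC[C@@H]1[C@@]2(C)CCC(=O)C(C)(C)[C@H]2CC[C@@]1(C)O` gives 46100 nM, and the step of a 1.6-fold higher number from compound 1 to compound 2 (0.21 log units; within the scatter) stays within the scatter. Compound 3 `C/C(=C\CC/C(C)=C/CC[C@@H]1[C@@]2(C)CCC(=O)C(C)(C)[C@H]2CC[C@@]1(C)O)CC/C=C(\C)C(=O)OCc1cn(-c2ccccc2C(F)(F)F)nn1` gives only > 150000 nM, which is a limit of this assay and not a number (the limit of > 150000 nM in this assay, at which 1 of the 3 values shown sits). Compound 4 `C/C(=C\CC/C(C)=C/CC[C@@H]1[C@@]2(C)CCC(=O)C(C)(C)[C@H]2CC[C@@]1(C)O)CC/C=C(\C)C(=O)OCc1cn(-c2ccccc2)nn1` differs from compound 1 by hydrogen in place of hydroxy on an aromatic carbon. The step of an at least 5.2-fold higher number from compound 1 to compound 3 (0.72 log units; beyond the scatter) also replaces the 3-hydroxyphenyl, though by 2-(trifluoromethyl)phenyl rather than by phenyl, so it bears on the present change only in part; the step of a 1.6-fold higher number from compound 1 to compound 2 (0.21 log units; within the scatter) shows that exchanging the whole triazole substituent cost little. A modest rise in this assay is therefore expected, a 1.8-fold higher number from compound 1 to compound 4 (0.25 log units; within the scatter). Compound 4 is estimated at 50000 nM, between 20000 nM and 130000 nM.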

Compound 4, half-maximal inhibitory concentration: 95500 nM
Beside the measured number, compound 4's estimate is 1.9-fold (0.28 log units) below it; low and high end bracket the measured number.
By their numbers in this assay, from the lowest: compounds 1 and 2 (each within the scatter of the next); then compound 4. At a limit, above all of these: compound 3.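

Removing the hydroxy alone is a modest loss in this assay: a 3.4-fold higher number from compound 1 to compound 4 (0.53 log units; beyond the scatter). The triazole is thus not interchangeable with ethynyl in every case, since without the hydroxy the comparison gives a 2.1-fold higher number from compound 2 to compound 4 (0.32 log units; beyond the scatter), whereas compound 1 and compound 2 stay within the scatter of each other. Compound 3 stands at a limit and not at a number: the limit of > 150000 nM in this assay, at which 1 of the 4 values shown sits. The step from that limit can be read only as a floor: an at least 1.5-fold lower number from compound 3 to compound 4 (0.19 log units; that floor lies within the scatter).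

Open, going by these compounds, is whether the hydroxy itself is needed on this aromatic carbon, or whether a methoxy or an amine there would hold the value of compound 1. Also open, on these data alone, is whether the hydroxy counts on other carbons of the ring.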